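A Methyl Added to the Chain Carbon of Compound 1

The compounds below may be only part of what the source reports. "The series", "measured", "known", "first", "only" and "open" are said of these compounds alone.

Measured in an ADME assay on MDBK cells (Bos taurus) for cytotoxicity; on this read-out higher numbers stand for lower toxicity in this test and lower numbers for higher toxicity in this test:
- compound 1 `c1ccc(Cn2ccc3nc(-c4ccccc4)nc-3c2)cc1`: > 100000 nM
- compound 2 `FC(F)(F)c1ccccc1Cn1ccc2nc(-c3ccccc3)nc-2c1`: > 100000 nM
- compound 3 `CC(C)(C)c1ccc(Cn2ccc3nc(-c4ccccc4)nc-3c2)cc1`: 22000 nM

Compound 1 gives > 100000 nM, which is a limit of the assay and not a number. Compound 2 gives > 100000 nM, also a limit. Together they make up (the limit of > 100000 nM in this assay, at which 2 of the 3 values shown sit). For the measured compounds named here, compound 3 is the only one with a true number.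

Compound 4 `CC(c1ccccc1)n1ccc2nc(-c3ccccc3)nc-2c1` differs from compound 1 in one place: methyl in place of hydrogen on a saturated chain carbon bound to an aromatic carbon and an aromatic nitrogen. The new methyl sits on a saturated chain carbon bound to an aromatic carbon and an aromatic nitrogen.

Going by the values given here, no measured step touches that carbon. The nearest guides are changes on an aromatic carbon, so they guide only loosely. Trifluoromethyl gives a step that the two limits leave unreadable from compound 1 to compound 2. Tert-butyl gives an at least 4.5-fold lower number from compound 1 to compound 3 (0.65 log units; beyond the scatter). That second step is the only readable one, so any shift in this assay is expected towards a lower number, though none beyond the scatter is the likelier outcome. The expected step is an at least 1.1-fold lower number from compound 1 to compound 4 (0.04 log units; that floor lies within the scatter). For compound 4 the estimated value is 90000 nM, with an expected range of 35000 nM to 100000 nM.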

Compound 4, half-maximal cytotoxic concentration: > 100000 nM
Compound 4: a limit, no number (the forecaster's own chance of this, stated with the estimate: 65%); middle value at least 1.1-fold (0.04 log units) from the limit.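

For the compounds shown here, compound 4 gives a limit of the assay and not a number, as compound 1 does, so no step between these two compounds can be read: the limit of > 100000 nM in this assay, at which 3 of the 4 values shown sit. The compounds shown leave open whether methyl on this saturated chain carbon changes the result in this assay at all.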